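Swapping Sulfamoyl for Nitro: Expected Tolerance of Compound 4

The source may hold more compounds than are shown below. What is called first, only, known or untested is meant among the compounds shown, and "the series" means these compounds.

Three compounds have been measured in a toxicity assay on MT4 cells (Homo sapiens) for cytotoxicity, read by MTT assay, with a stated time of 5 days; a higher number here means that more compound is tolerated, a lower number that less compound is tolerated:

- compound 1, `Cc1ccc(C(C)C)c(OCC(=O)NNC(=S)NCc2ccccc2)c1`, gives 12.6 ug/mL
- compound 2, `CC(=O)Nc1ccc(OCc2n[nH]c(=S)n2Cc2ccccc2)cc1`, gives 79 ug/mL
- compound 3, `Cc1ccc(C(C)C)c(OCc2nnc(SCC(=O)Nc3ccc(S(N)(=O)=O)cc3)n2Cc2ccccc2)c1`, gives 13 ug/mL

Among these three numbers, compound 3 holds the second highest. Its nearest neighbour is compound 1, and the two values lie within the usual scatter of each other, so no order between them can be read. Compound 2 is the furthest away, with a higher number that lies beyond the scatter, meaning that more of compound 2 is tolerated by the cells than of compound 3.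

Compound 4, `Cc1ccc(C(C)C)c(OCc2nnc(SCC(=O)Nc3ccc([N+](=O)[O-])cc3)n2Cc2ccccc2)c1`, has not yet been measured. It differs from compound 3 in one place: nitro in place of sulfamoyl on an aromatic carbon. Among the measured compounds shown here, no measured pair in this set shows what this exchange does in this assay, so there is no directly comparable step to lean on. With nothing in the data pointing to a large shift, the most reasonable expectation is a step that stays within the scatter, perhaps leaning towards a slightly lower number. The step this expectation implies, a 1.3-fold lower number from compound 3 to compound 4 (0.11 log units; within the scatter), is expected to be small. Compound 4 is therefore estimated at about 10 ug/mL, with a range from 4 ug/mL to 30 ug/mL.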

Compound 4, half-maximal cytotoxic concentration: 11.2 ug/mL
For compound 4 the middle estimate is 1.1-fold (0.05 log units) below the measured one; the range from low to high includes it.
By their numbers in this assay, from the lowest: compounds 4, 1 and 3 (each within the scatter of the next); then compound 2.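

Swapping the groups at this position gives a 1.2-fold lower number from compound 3 to compound 4 (0.06 log units; within the scatter) in this assay, the first direct comparison in this set of two compounds that differ in one place only. The change sits on an aromatic carbon, para to a large group, and no order can be read between the two compounds. Sulfamoyl brings a sulfur and a hydrogen-bond donor and nitro brings neither, yet in this single pair, losing both leaves the cells' tolerance indistinguishable within the usual scatter of the assay, and nothing available here explains why the two results lie so close together.

Going by these compounds, a single pair cannot show whether this position accepts other groups equally well, so it remains open what an amine, a carboxylic acid or a longer chain ending in either would do on the same aromatic ring. Among the compounds shown here, it also remains open whether the same exchange would read the same way on a different core, as compound 1 and compound 2 differ from these two compounds in more than one place and offer no second example.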